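The source may hold more compounds than are shown below. What is called first, only, known or untested is meant among the compounds shown, and "the series" means these compounds.

Compound 1, `COc1cc(-c2nn(-c3cccc(NC(=O)Nc4cc(C(F)(F)F)cc(C(F)(F)F)c4)c3)cc2-c2ccncc2)ccc1Cl`, reaches only the limit > 50000 nM in a functional assay on SF-268 cells (Homo sapiens) for inhibition, read by sulforhodamine B assay, with a stated time of 48 h; a higher number here means that more compound is tolerated, a lower number that less compound is tolerated.
Compound 2, `COc1cc(-c2nn(-c3cccc(NC(=O)Nc4ccc(Cl)c(Cl)c4)c3)cc2-c2ccncc2)ccc1Cl`, reaches only the limit > 50000 nM in this assay.
Compound 3, `O=C(Nc1cccc(-n2cc(-c3ccncc3)c(-c3ccc(Cl)c(O)c3)n2)c1)Nc1ccc(Cl)c(Cl)c1`, reaches only the limit > 32500 nM in this assay.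

Each of these three values is a limit of this assay and not a number. Compound 2 therefore stands nowhere on a scale: its value is a limit, and the two further values shown are limits as well, two of them sitting at the limit of > 50000 nM in this assay, at which 2 of the 3 values shown sit, and one at the limit of > 32500 nM in this assay, at which 1 of the 3 values shown sits. The only measured step that connects two of these compounds, a step that the two limits leave unreadable from compound 2 to compound 3, is hydrogen in place of methyl on an oxygen on an aromatic ring, and its size cannot be read from two limits.

Compound 4, `COc1cc(-c2nn(-c3cccc(NC(=O)Nc4ccc(Cl)c(C(F)(F)F)c4)c3)cc2-c2ccncc2)ccc1Cl`, is the next member to be measured in this assay. It differs from compound 2 by trifluoromethyl in place of chloro on an aromatic carbon. No measured step touches the ring that carries this change, so nothing shown bears on it directly, and nothing in the three limits points to a readable step in either direction. The step that the limit leaves unreadable from compound 2 to compound 4 is therefore expected to stay within the scatter, most likely with the assay again reporting only a limit.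

For compound 4 the estimate in this assay is 60000 nM, with a range from 30000 nM to 150000 nM.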

Compound 4, concentration lethal to 50% of the cells: > 32500 nM
Compound 4: a limit, no number; the forecaster's own chance of this, stated with the estimate: 85%; the middle value is on the limit's open side.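

In this assay compound 4 gives > 32500 nM, a limit and not a number. Within the data shown here, compound 2 also stands only at a limit, and no step from compound 2 to compound 4 can be read. The compounds shown leave open where any of them falls on a numerical scale, and whether trifluoromethyl in place of chloro shifts the value at all.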